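Adding a Methoxy Group to Compound 1

This account rests on a few compounds, and the source may have more. Where it says the series, first, only, none or still open, it means among the compounds named here.

Among the compounds with values here, compound 1 `N=C(N)c1ccc(-c2ccc(-c3ccccc3)s2)cc1F` stands highest of the two numbers measured so far in a functional assay on PC-3 cells (Homo sapiens) for inhibition, read by sulforhodamine B assay, with a stated time of 48 h (a higher number here means a weaker inhibitor of growth, a lower number a stronger inhibitor of growth), where compound 1 gives 4180 nM. Compound 2 `COc1cc(OC)cc(-c2ccc(-c3ccc(C(=N)N)cc3)s2)c1` gives 1800 nM in this assay, a gap beyond the usual scatter. Compound 3 `COc1ccc(-c2ccc(-c3ccc(C(=N)N)c(F)c3)s2)cc1` differs from compound 1 by methoxy in place of hydrogen on an aromatic carbon. Within the data shown here, no pair of measured compounds isolates this change; since compound 2, which carries methoxy groups, shows the lower number 1800 nM, a small move toward stronger growth inhibition is expected, of size a 1.6-fold lower number from compound 1 to compound 3 (0.21 log units; within the scatter). For compound 3 the estimate is 2600 nM, with a range from 1000 nM to 6500 nM.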

Compound 3, concentration for 50% growth inhibition: 4050 nM
Compound 3: the middle estimate sits 1.6-fold (0.19 log units) below what was measured; the measured number falls inside the stated range.
By their numbers in this assay, from the lowest: compound 2; then compounds 3 and 1 (each within the scatter of the next).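

Methoxy in place of hydrogen on this aromatic carbon, para to a large group, gives a 1.0-fold lower number from compound 1 to compound 3 (0.01 log units; within the scatter) in this assay. Within the data shown here, this is the only comparison so far that isolates one change, and it shows that methoxy here leaves growth inhibition unchanged within the scatter. Nothing measured here offers a reason for this result.

Compound 2 differs from compound 3 in more than one place, so the source of its lower number stays unresolved. From the compounds shown here alone, how an amine or a carboxylic acid would read at this position also remains open.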